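Swapping the furan attachment in an ester series

A few compounds are considered here, and "the series" means these few. Any claim that something is new, unique, unknown or untested is made for them only; others in the source may bear on it.

Compound 1 `CC1=C(C(=O)OC(C(F)(F)F)C(F)(F)F)C(c2ccoc2)NC(=O)N1` was examined in an assay on cells for displacement of a labelled ligand from adenosine receptor A1 (Homo sapiens), read by radioligand binding, with a stated time of 60 min, tested at 1 uM (on this read-out higher numbers stand for more inhibition at the one concentration tested (going by the name of the read-out) and lower numbers for less inhibition), where compound 1 gives 7%. Its closest relative, compound 3 `CC1=C(C(=O)OCC(F)(F)F)C(c2ccoc2)NC(=O)N1`, gives 13%, and compound 2 `CC1=C(C(=O)OC(C)C(F)(F)F)C(c2ccoc2)NC(=O)N1` gives 10%; 1% (2 entries). Compound 1 thus holds the smaller of the two single figures, yet the step of a number 6 percentage points higher from compound 1 to compound 3 (within the scatter) lies within the scatter, and the repeated readings of compound 2 the several entries of compound 2 in this assay, 10%; 1% (2 entries) show how broad that scatter is. Compound 4 `CC1=C(C(=O)OC(C(F)(F)F)C(F)(F)F)C(c2ccco2)NC(=O)N1` differs from compound 1 only in one respect: furan-2-yl in place of furan-3-yl on a saturated ring carbon. Among the measured compounds shown here, no measured step bears on this change; the single measured step concerns the ester group. The expectation for compound 4 is therefore a step of no more than the scatter, a number 1 percentage points higher from compound 1 to compound 4 (within the scatter). Compound 4 is estimated at 8%, with a range from -5% to 22%.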

Compound 4, a percentage reported as inhibition, at one concentration (the size of the read-out at that concentration, not a potency): 6%
Estimate against measurement, compound 4: 2 percentage points above, and the stated range covers the measured number.
By their numbers in this assay, from the lowest: compounds 4, 1 and 3 (each within the scatter of the next).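

The earlier compounds shown here varied only the ester group, and all carried furan-3-yl; here the ring itself is touched, and furan-2-yl in place of furan-3-yl on a saturated ring carbon gives a number 1 percentage points lower from compound 1 to compound 4 (within the scatter) in this assay. The attachment of the furan thus makes no readable difference at this position, with this ester. How little so small a gap can carry is seen in the repeated readings: the several entries of compound 2 in this assay, 10%; 1% (2 entries)

Going by these compounds, whether the same swap behaves alike with the ester of compound 3 stays open. So does what a phenyl or pyridine ring would give at this position.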